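The compounds below may be only part of what the source reports. "The series", "measured", "known", "first", "only" and "open" are said of these compounds alone.

Measured so far in an assay on isolated protein for inhibition of alkaline phosphatase, tissue-nonspecific isozyme (Homo sapiens); a lower number here means a stronger inhibitor, a higher number a weaker inhibitor:
Compound 1 `COc1ccc(Cl)cc1S(=O)(=O)Nc1cncc(-c2cccnc2)c1`: 73 nM
Compound 2 `COc1ccc(Cl)cc1S(=O)(=O)Nc1cncc(C(=O)O)c1`: 134 nM

Compound 2 stands alongside compound 1: the step of a 1.8-fold higher number from compound 1 to compound 2 (0.26 log units; within the scatter) lies within the scatter, so the two values cannot be told apart. Compound 3 `COc1ccc(Cl)cc1S(=O)(=O)Nc1cncc(-c2ccc(C)cc2)c1` has not been measured. It differs from compound 2 by 4-methylphenyl in place of carboxy on an aromatic carbon. For the measured compounds named here, the one measured step that bears on this change, replacing an aromatic ring by carboxy, was small, and compound 3 again carries an aromatic ring in that place. A small step in this assay is therefore expected, if anything toward a lower number. The expected step is a 1.8-fold lower number from compound 2 to compound 3 (0.25 log units; within the scatter). Compound 3 is estimated at 75 nM, within a range from 25 nM to 220 nM.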

Compound 3, half-maximal inhibitory concentration: 147 nM
For compound 3 the middle estimate is 2.0-fold (0.29 log units) below the measured one; the range from low to high includes it.
By their numbers in this assay, from the lowest: compounds 1, 2 and 3 (each within the scatter of the next).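

In this assay, 4-methylphenyl at this position gives a 1.1-fold higher number from compound 2 to compound 3 (0.04 log units; within the scatter) and, against pyridin-3-yl, a 2.0-fold higher number from compound 1 to compound 3 (0.30 log units; within the scatter). Carboxy and 4-methylphenyl differ in size and in hydrogen-bond donors and acceptors, yet this change leaves the two values indistinguishable, and the same holds for the three compounds taken step by step. No measurement at hand gives a reason for this. Still open, on these data alone, is whether an amine or a longer alkyl chain at this position would stand apart from these three values.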